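The source may hold more compounds than are shown below. What is called first, only, known or untested is meant among the compounds shown, and "the series" means these compounds.

Compound 1 `Cc1cc(-c2c(O)nc3cc(Cl)c(C(=O)Nc4ccncn4)cc3c2OCC[C@@H]2CCCN2)cc(C)c1C`: in an assay on CHO cells for binding affinity to Gonadotropin-releasing hormone receptor (Homo sapiens), read by radioligand binding (a lower number here means a stronger inhibitor, a higher number a weaker inhibitor), compound 1 gives 0.8 nM.
Compound 2 `Cc1cc(-c2c(O)nc3cc(Cl)c(C(=O)Nc4cnsn4)cc3c2OCCC2COCCN2)cc(C)c1C`: in this assay compound 2 gives 0.7 nM.

The two numbers lie within the usual scatter of each other, so compound 1 and compound 2 cannot be ranked; compound 1 simply stands level with compound 2. Compound 3 `Cc1cc(-c2c(O)nc3cc(Cl)c(C(=O)Nc4ccncn4)cc3c2OCCC2CCCO2)cc(C)c1C` is not yet measured. It differs from compound 1 in one place: oxolan-2-yl in place of pyrrolidin-2-yl on a saturated chain carbon, two bonds along the chain from an oxygen on an aromatic ring. Among the measured compounds shown here, no step between measured compounds covers this change, so nothing measured sets its size; a modest weakening is expected, as the step of a 3.8-fold higher number from compound 1 to compound 3 (0.57 log units; beyond the scatter). For compound 3 the expected value is 3 nM, within a range from 0.8 nM to 12 nM.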

Compound 3, half-maximal inhibitory concentration: 0.6 nM
Estimate against measurement, compound 3: 5.0-fold (0.70 log units) above; the whole stated range lies above it.
By their numbers in this assay, from the lowest: compounds 3, 2 and 1 (each within the scatter of the next).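

Putting oxolan-2-yl in place of pyrrolidin-2-yl on a saturated chain carbon, two bonds along the chain from an oxygen on an aromatic ring, gives a 1.3-fold lower number from compound 1 to compound 3 (0.12 log units; within the scatter) in this assay, so the two compounds stand level. At this position, then, a ring with 0 hydrogen-bond donors and no defined stereocentre matches one with 1 donor and 1 defined stereocentre. No available evidence explains this result. Still open, going by these compounds, is whether the ring's hetero atom is needed at all, which a cyclopentyl group could test, and whether a longer chain would keep the value.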